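The compounds below may be only part of what the source reports. "The series", "measured", "known", "first", "only" and "open" are said of these compounds alone.

Measured so far in an ADME assay on microsomes from liver (Homo sapiens) for metabolic stability, using NADPH, with a stated time of 10 min; a higher number here means that more of the compound is left, a lower number that less of the compound is left:

Compound 1 `NC/C=C/CN(C[C@H]1Cc2ncccc2CN1)[C@H]1CCCc2cccnc21` gives 85%.
Compound 2 `NC(=O)NC/C=C/CN(C[C@H]1Cc2ncccc2CN1)[C@H]1CCCc2cccnc21` gives 93%.

Compound 1 stands lowest of the two numbers; its nearest neighbour is compound 2, and the step of a number 8 percentage points higher from compound 1 to compound 2 (within the scatter) lies within the scatter, so both compounds sit in the same high band of this assay.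

Compound 3 `c1cnc2c(c1)CN[C@@H](CN(CCCC1CCNCC1)[C@H]1CCCc3cccnc31)C2` is not yet measured. It differs from compound 1 by 2-(piperidin-4-yl)ethyl in place of 3-aminoprop-1-en-1-yl on a saturated chain carbon bound to an amine nitrogen.

Among the compounds with values here, the only measured step concerns a carbamoyl in place of hydrogen on an amine nitrogen and shows no movement beyond the scatter; it does not touch the chain that is exchanged in compound 3, so it bears on the new step only in that the series so far sits high and has tolerated one change without loss. Within the data shown here, there is no measured step in which a chain is replaced.

Compound 3 is therefore expected to stay in the same high band, with the step of a number 5 percentage points lower from compound 1 to compound 3 (within the scatter) estimated as none beyond the scatter, and its value estimated at 80%, between 60% and 95%.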

Compound 3, percent of the compound remaining: 100%
Estimate against measurement, compound 3: 20 percentage points below, and the stated range ends below it.
By their numbers in this assay, from the lowest: compounds 1, 2 and 3 (each within the scatter of the next, the first and the last beyond it).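

In this assay, this position responds where the carbamoyl change did not: 2-(piperidin-4-yl)ethyl in place of 3-aminoprop-1-en-1-yl gives a number 15 percentage points higher from compound 1 to compound 3 (beyond the scatter), a modest step. Set against the carbamoyl-bearing chain, the same group gives a number 7 percentage points higher from compound 2 to compound 3 (within the scatter), so the larger chain with its six-membered non-aromatic ring is accepted here without loss, and compound 2 and compound 3 cannot be ordered. Nothing at hand accounts for the step from compound 1.

Open, going by these compounds, is whether the ring or the saturated chain goes with the higher number; an open-chain 5-aminopentyl group at this position would separate the two. Also open, on these data alone, is how the position answers to a group without the ring nitrogen, such as a cyclohexyl-ended chain, or to a terminal carboxylic acid.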